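The source may hold more compounds than are shown below. What is called first, only, known or untested is meant among the compounds shown, and "the series" means these compounds.

Compound 1 `Clc1ccc(-c2cc(-c3ccsc3)nc(-c3ccccn3)c2)o1`: 21900 nM
Compound 2 `Clc1ccc(-c2cc(-c3ccco3)cc(-c3cccs3)n2)cc1`: > 100000 nM

In a functional assay on K562 cells (Homo sapiens) for cytotoxicity, in the presence of a further agent that is not named here (a higher number here means a weaker inhibitor, a lower number a stronger inhibitor), compound 1 gives 21900 nM. Compound 1 holds the only number shown here, since the other value is a limit. In this assay compound 2 gives > 100000 nM, which is a limit of the assay and not a number. Compound 3 `Cc1ccc(-c2cc(-c3ccc(Cl)o3)cc(-c3ccsc3)n2)cc1` has not yet been measured. It differs from compound 1 in one place: 4-methylphenyl in place of pyridin-2-yl on an aromatic carbon. Among the measured compounds shown here, no step between measured compounds is known; the only guide is the limit at which compound 2 sits (the limit of > 100000 nM in this assay, at which 1 of the 2 values shown sits). A loss beyond the scatter is expected, a 2.7-fold higher number from compound 1 to compound 3 (0.44 log units; beyond the scatter). Compound 3 is estimated at 60000 nM, within 20000 nM to 150000 nM.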

Compound 3, half-maximal inhibitory concentration: 19900 nM
Compound 3: middle estimate off by 3.0-fold (0.48 log units), on the high side, outside the stated range (below it).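

In this assay, putting 4-methylphenyl in place of pyridin-2-yl gives a 1.1-fold lower number from compound 1 to compound 3 (0.04 log units; within the scatter), so the two compounds cannot be told apart. This position, next to the ring nitrogen, therefore accepts a ring of carbon only as well as one with a nitrogen, and the hydrogen-bond acceptor of pyridin-2-yl is not needed in this pair. Nothing shown gives a cause for this. As far as these compounds go, it remains open whether an amine or a carboxylic acid at this position would hold the value, and whether the methyl group of 4-methylphenyl contributes anything.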